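A few compounds are considered here, and "the series" means these few. Any claim that something is new, unique, unknown or untested is made for them only; others in the source may bear on it.

Compound 2 `NC1=NC2(CCSCC2)N(OCCCOc2cccc(Cl)c2Cl)C(N)=N1` and compound 1 `NC1=NC2(CCSCC2)N(OCCCOc2ccc(Cl)c(Cl)c2)C(N)=N1` share one core and differ only in the placement of two chloro groups. In an assay on isolated protein for inhibition of Dihydrofolate reductase (Homo sapiens), read by spectrophotometry, using NADPH, with stated times of 5 s and 6 min, tested at 5 uM (on this read-out lower numbers stand for a weaker effect and higher numbers for a stronger effect at the one concentration tested), compound 1 gives 88.4%, and compound 2 gives 83.8%, so the two numbers sit within the usual scatter of each other, as the step of a number 4.6 percentage points lower from compound 1 to compound 2 (within the scatter) shows. Compound 3 `NC1=NC2(CCSCC2)N(OCCCOc2ccccc2Cl)C(N)=N1` takes the next step: hydrogen in place of chloro on an aromatic carbon. Among the compounds with values here, no measured step removes a chloro group; the only step known moves one and was within the scatter, so a modest change is expected at most. On that basis compound 3 is estimated at 75%, between 55% and 92%, an expected step of a number 8.8 percentage points lower from compound 2 to compound 3 (within the scatter).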

Compound 3, a percentage reported as inhibition, at one concentration (the size of the read-out at that concentration, not a potency): 86.3%
Compound 3: the middle estimate sits 11.3 percentage points below what was measured, and the stated range covers the measured number.
By their numbers in this assay, from the lowest: compounds 2, 3 and 1 (each within the scatter of the next).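

Where the earlier pair only moved a chloro group, compound 3 loses one outright, and in this assay the read-out shows a number 2.5 percentage points higher from compound 2 to compound 3 (within the scatter). The comparison with the 3,4-dichlorophenyl compound gives a number 2.1 percentage points lower from compound 1 to compound 3 (within the scatter), so at this one concentration, a ring with a single chloro group cannot be told apart from either ring with two. Nothing measured here explains this. The compounds shown leave open what happens when the last chloro group goes too, leaving plain phenyl, and whether an amine or a carboxylic acid on that ring would be tolerated.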